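From Chloro to Hydroxy at the Assay Limit

A few compounds are considered here, and "the series" means these few. Any claim that something is new, unique, unknown or untested is made for them only; others in the source may bear on it.

In a functional assay on Vero cells (Chlorocebus sabaeus) for inhibition (on this read-out lower numbers stand for stronger inhibition and higher numbers for weaker inhibition), compound 1 `Nc1nc(Cl)c2ncn([C@H]3CS[C@@H](CO)O3)c2n1` gives > 100000 nM, which is a limit of the assay and not a number. Its partner in configuration, compound 2 `Nc1nc(Cl)c2ncn([C@@H]3CS[C@@H](CO)O3)c2n1`, gives > 100000 nM, again only a limit. That leaves a step that the two limits leave unreadable from compound 1 to compound 2, and compound 1 stands at the limit of > 100000 nM in this assay, at which 2 of the 3 values shown sit. Compound 3 `OC[C@H]1O[C@@H](n2cnc3c(Cl)ncnc32)CS1` gives a true number, 46500 nM. The change there, hydrogen in place of amino on an aromatic carbon, is an at least 2.1-fold lower number from compound 1 to compound 3 (0.33 log units; beyond the scatter).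

Compound 4 `Nc1nc(O)c2ncn([C@H]3CS[C@@H](CO)O3)c2n1` keeps the rest of compound 1 and differs by hydroxy in place of chloro on an aromatic carbon. Going by the values given here, no measured step alters the chloro, so the size of this change has no direct guide. The one readable move, an at least 2.1-fold lower number from compound 1 to compound 3 (0.33 log units; beyond the scatter), came with loss of the amino group, which compound 4 keeps. The estimated change is a number no higher from compound 1 to compound 4 (the limit leaves the size open), with no step beyond the scatter expected in either direction. For compound 4 the expected value is 100000 nM, with an estimated range from 40000 nM to 200000 nM.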

Compound 4, half-maximal inhibitory concentration: > 100000 nM
Compound 4: a limit, no number; the forecaster's own chance of this, stated with the estimate: 75%; the middle value lies on the limit itself.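

In this assay compound 4 gives > 100000 nM which is a limit of the assay and not a number. Compound 1 also stands at a limit, and no step can be read between the two. The compounds shown leave open whether hydroxy in place of chloro on an aromatic carbon changes inhibition at all.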